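The source may report more compounds than this note shows. Statements on the series, on what has been measured and on what is new or still open speak of the compounds shown alone.

Of the compounds shown here, three sharing one core have been tested in an assay on HEK293 cells for inhibition of Voltage-dependent T-type calcium channel subunit alpha-1G (Homo sapiens), read by patch clamp; on this read-out lower numbers stand for stronger inhibition and higher numbers for weaker inhibition. Compound 1 `CCCc1nc(-c2ccccc2)c(CNCCN2CCN(c3ccc(Cl)cc3)CC2)o1` gives 2820 nM. Compound 2 `CCCc1nc(-c2ccccc2)c(CNCCN2CCN(c3ccc(OC)cc3)CC2)o1` gives 9200 nM. Compound 3 `CCCc1nc(-c2ccccc2)c(CNCCN2CCN(c3ccc(C(F)(F)F)cc3)CC2)o1` gives 1300 nM, the lowest of the three numbers. The step of a 2.2-fold lower number from compound 1 to compound 3 (0.34 log units; beyond the scatter) and the step of a 7.1-fold lower number from compound 2 to compound 3 (0.85 log units; beyond the scatter) both favour the trifluoromethyl-bearing group over the other two groups attached at the amine nitrogen in a ring. Compound 4 `CCCc1nc(-c2ccccc2)c(CNCCN2CCN(c3cccc(F)c3)CC2)o1` carries 3-fluorophenyl in place of 4-(trifluoromethyl)phenyl on an amine nitrogen in a ring. Going by the values given here, no measured step involves a 3-fluorophenyl group, so the expectation rests only on the observation that each departure from trifluoromethyl so far raised the number in this assay. The expected step of a 2.7-fold higher number from compound 3 to compound 4 (0.43 log units; beyond the scatter) is therefore a modest rise. Compound 4 is estimated at 3500 nM, within 1500 nM to 9000 nM.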

Compound 4, half-maximal inhibitory concentration: 3350 nM
Beside the measured number, compound 4's estimate is 1.0-fold (0.02 log units) above it; low and high end bracket the measured number.
By their numbers in this assay, from the lowest: compound 3; then compounds 1 and 4 (each within the scatter of the next); then compound 2.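

In this assay, swapping the group on the ring nitrogen for 3-fluorophenyl gives a 2.6-fold higher number from compound 3 to compound 4 (0.41 log units; beyond the scatter), while the same kind of swap gives a 2.7-fold lower number from compound 2 to compound 4 (0.44 log units; beyond the scatter). Against 4-chlorophenyl, the change gives a 1.2-fold higher number from compound 1 to compound 4 (0.07 log units; within the scatter), so these two groups cannot be told apart here. Nothing available explains these steps. 3-Fluorophenyl differs from the other three groups in both its substituent and that substituent's place on the phenyl ring, and these compounds cannot separate the two changes. From the compounds shown here alone, how a 4-fluorophenyl group, or a phenyl ring carrying a nitrile or an amine, would read also remains open.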